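The compounds below may be only part of what the source reports. "The series", "measured", "known", "first", "only" and "open" are said of these compounds alone.

Compound 1 `Cc1ccc(/C=C/C(=O)Nc2nnc(-c3ccc(C)cc3)s2)cc1`: in a functional assay on MCF7 cells (Homo sapiens) for antiproliferative activity, read by MTT assay, with a stated time of 48 h (a higher number here means a weaker inhibitor, a lower number a stronger inhibitor), compound 1 gives 0.61 ug/mL.
Compound 2 `Cc1ccc(-c2nnc(NC(=O)/C=C/c3ccccc3)s2)cc1`: in this assay compound 2 gives 1.19 ug/mL.
Compound 3 `Cc1ccc(-c2nnc(NC(=O)/C=C/c3ccc(F)cc3)s2)cc1`: in this assay compound 3 gives 1.27 ug/mL.

Among these three, compound 1 has the lowest number. Its nearest neighbour stands at the step given by a 2.0-fold higher number from compound 1 to compound 2 (0.29 log units; within the scatter), and its furthest at the step given by a 2.1-fold higher number from compound 1 to compound 3 (0.32 log units; beyond the scatter). Between the two neighbours themselves there is only a 1.1-fold higher number from compound 2 to compound 3 (0.03 log units; within the scatter), so compounds 2 and 3 cannot be told apart.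

Compound 4 `COc1ccc(-c2nnc(NC(=O)/C=C/c3ccc(C)cc3)s2)cc1` has not yet been measured. It differs from compound 1 in one place: methoxy in place of methyl on an aromatic carbon. Within the data shown here, no measured step touches this position: the steps on record all concern a methyl on a different aromatic carbon, where hydrogen or fluoro took its place and the number rose by about the scatter or a little more. They show that losing or exchanging a methyl on an aromatic ring in this series has cost little, but they say nothing direct about a methoxy. The expectation is therefore a step of the same small order, at most a modest rise, and quite possibly none beyond the scatter. Compound 4 is estimated at 0.85 ug/mL, within 0.4 ug/mL to 1.8 ug/mL. This estimate means an expected step of a 1.4-fold higher number from compound 1 to compound 4 (0.14 log units; within the scatter).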

Compound 4, half-maximal inhibitory concentration: 0.31 ug/mL
For compound 4 the middle estimate is 2.7-fold (0.44 log units) above the measured one; the whole stated range lies above it.
By their numbers in this assay, from the lowest: compounds 4, 1, 2 and 3 (each within the scatter of the next, the first and the last beyond it).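

Among these compounds, the result is the first reading at this position, the aromatic carbon that carries the methyl of the 4-methylphenyl group in compound 1, and the earlier steps concerned only the methyl on the other aromatic ring. In this assay, the change from 4-methylphenyl to 4-methoxyphenyl gives a 2.0-fold lower number from compound 1 to compound 4 (0.29 log units; within the scatter), so compounds 1 and 4 cannot be told apart, and this position accepts a methoxy, with its added oxygen and hydrogen-bond acceptor, without a shift beyond the scatter. Nothing among the data available here accounts for this outcome, which therefore stands as an observation about these two compounds only.

The compounds shown leave open how far this tolerance extends at the same position, since a single exchange cannot show whether a hydroxyl, an amine, a chlorine or a longer chain such as ethoxy would behave as methoxy does. They also leave open whether hydrogen or fluoro at this position would give the small steps seen on the other ring, and whether a methoxy on that other ring would match the one here.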